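A few compounds are considered here, and "the series" means these few. Any claim that something is new, unique, unknown or untested is made for them only; others in the source may bear on it.

Going by the values given here, compound 1, whose structure is `O=C1/C(=C2/C(=O)N([C@@H]3O[C@H](CO)[C@H](O)[C@H](O)[C@H]3O)c3ccccc32)Nc2ccccc21`, is the weakest inhibitor among the three compounds measured so far. In a functional assay on KYSE-70 cells (Homo sapiens) for antiproliferative activity, read by crystal violet staining, with a stated time of 96 h (a lower number here means a stronger inhibitor, a higher number a weaker inhibitor), compound 1 gives 41500 nM. Its nearest neighbour by number is compound 3, `C[C@@H]1O[C@H](N2C(=O)/C(=C3\Nc4ccccc4\C3=N/O)c3ccccc32)[C@H](O)[C@H](O)[C@H]1O`, which in this assay gives 15400 nM; the furthest is compound 2, `C[C@@H]1O[C@H](N2C(=O)/C(=C3\Nc4ccc(Cl)cc4C3=O)c3ccccc32)[C@H](O)[C@H](O)[C@H]1O`, which in this assay gives 5940 nM. Both gaps lie beyond the scatter of repeated measurements, so compound 1 stands clearly at the high end of the numbers shown.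

The step under consideration leads from compound 1 to compound 4, whose structure is `O=C1/C(=C2/C(=O)N([C@@H]3O[C@H](CO)[C@@H](O)[C@H](O)[C@H]3O)c3ccccc32)Nc2ccccc21`. The change is the two compounds have the same atoms and bonds and differ only in configuration as drawn: 1 of 6 stereo elements differ; a stereocentre at a saturated ring carbon is drawn R in compound 1 and S in compound 4. No atoms leave and none enter; the sugar is the same in its atoms and bonds, and only the configuration at one saturated ring carbon is altered.

Among the compounds with values here, there is no measured pair in this set that shares this kind of change, so no step can be borrowed from the data. With a change of configuration alone, at one centre of a sugar that does not touch the shared core, the account expects the step from compound 1 to compound 4 to be small, perhaps a modest move toward a lower number but quite possibly none beyond the scatter; the expected step is a 1.4-fold lower number from compound 1 to compound 4 (0.14 log units; within the scatter). On that basis compound 4 is estimated to give 30000 nM in this assay, with a likely range from 10000 nM to 90000 nM.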

Compound 4, half-maximal inhibitory concentration: 28900 nM
Compound 4: the middle estimate sits 1.0-fold (0.02 log units) above what was measured; the measured number falls inside the stated range.
By their numbers in this assay, from the lowest: compound 2; then compounds 3, 4 and 1 (each within the scatter of the next, the first and the last beyond it).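

In this assay the one inverted stereocentre at a saturated ring carbon of the sugar gives a 1.4-fold lower number from compound 1 to compound 4 (0.16 log units; within the scatter) and so stays within the scatter, which means that this assay does not separate the two configurations at this carbon. Going by these compounds alone, the earlier compounds offered no step of this kind, since none of them differed from another in one place, and this pair gives the first reading of a single change on the sugar. Nothing other than this centre can account for whatever lies between the two numbers, because the comparison is free of any change in atoms or bonds: the fact that compounds 1 and 4 differ only in the configuration as drawn.

The compounds shown leave open whether the other centres of the sugar tolerate inversion as this one does, and whether the same inversion would read alike on the core of compound 2 or compound 3. They also leave open what would follow if an amine took the place of the hydroxyl at this carbon, or if a carboxylic acid took the place of the hydroxymethyl group on the sugar.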